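Chloro added to the trifluoromethylphenyl urea of compound 3

The source may hold more compounds than are shown below. What is called first, only, known or untested is meant among the compounds shown, and "the series" means these compounds.

Measured so far:
compound 1, `COc1cc2cc(Oc3ccc(NC(=O)Nc4ccccc4)cc3)c(C)nc2cc1OC` — 42.7%
compound 2, `COc1cc2cc(Oc3ccc(NC(=O)Nc4ccc(C(F)(F)F)cc4)cc3)c(C)nc2cc1OC` — 59.6%
compound 3, `COc1cc2cc(Oc3ccc(NC(=O)Nc4cccc(C(F)(F)F)c4)cc3)c(C)nc2cc1OC` — -6.62%

In a functional assay on SR cells (Homo sapiens) for inhibition, read by sulforhodamine B assay, with a stated time of 48 h, tested at 10 uM (a lower number here means a stronger effect, a higher number a weaker effect of the compound at the concentration tested), compound 3 gives the lowest of the three numbers; the nearest is compound 1, through a number 49.3 percentage points lower from compound 1 to compound 3 (beyond the scatter), and the furthest is compound 2, through a number 66.2 percentage points lower from compound 2 to compound 3 (beyond the scatter). Compound 4, `COc1cc2cc(Oc3ccc(NC(=O)Nc4ccc(Cl)c(C(F)(F)F)c4)cc3)c(C)nc2cc1OC`, differs from compound 3 by chloro in place of hydrogen on an aromatic carbon. Among the compounds with values here, no measured step introduces a chloro group, so none bears directly on this change; the two steps into compound 3 only show that the 3-(trifluoromethyl)phenyl group sits at the strong end of the series. An additional chloro is therefore expected to leave the number near that of compound 3, with a step of a number 9.6 percentage points higher from compound 3 to compound 4 (within the scatter) not beyond the scatter. For compound 4 the estimate in this assay is 3%, ranging from -25% to 38%.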

Compound 4, a percentage reported as activity, at one concentration (the size of the read-out at that concentration, not a potency): -32.5%
Compound 4: the middle estimate sits 35.5 percentage points above what was measured, and the stated range ends above it.
By their numbers in this assay, from the lowest: compound 4; then compound 3; then compound 1; then compound 2.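

In this assay, chloro ortho to a trifluoromethyl group pushes the number further down, with a number 25.9 percentage points lower from compound 3 to compound 4 (beyond the scatter), so this ring position accepts a substituent and the number still falls. The 4-chloro-3-(trifluoromethyl)phenyl group also stands far from the other two aryl groups, with a number 92.1 percentage points lower from compound 2 to compound 4 (beyond the scatter) and with a number 75.2 percentage points lower from compound 1 to compound 4 (beyond the scatter). Nothing shown here explains this shift. As far as these compounds go, whether a fluoro or a methoxy at the same position would act like chloro remains open, as does whether chloro would lower the number without the trifluoromethyl group.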